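The compounds below may be only part of what the source reports. "The series", "measured", "known", "first", "only" and "open" are said of these compounds alone.

Compound 1 `O=C(Nc1cccc(-n2cc(-c3ccncc3)c(-c3cc(O)cc(Cl)c3)n2)c1)Nc1ccc(Cl)c(C(F)(F)F)c1` and compound 2 `COc1cc(Cl)cc(-c2nn(-c3cccc(NC(=O)Nc4ccc(Cl)c(C(F)(F)F)c4)c3)cc2-c2ccncc2)c1` share one core, while compound 3 `O=C(Nc1cccc(-n2cc(-c3ccncc3)c(-c3cc(O)cc(Cl)c3)n2)c1)c1cc(C(F)(F)F)cc(C(F)(F)F)c1` and compound 4 `COc1cc(Cl)cc(-c2nn(-c3cccc(NC(=O)c4cc(C(F)(F)F)cc(C(F)(F)F)c4)c3)cc2-c2ccncc2)c1` share another; how the core of compound 3 differs from that of compound 1 is not broken down here. In a functional assay on M14 cells (Homo sapiens) for inhibition, read by sulforhodamine B assay, with a stated time of 48 h, tested at 10 uM (on this read-out lower numbers stand for a stronger effect and higher numbers for a weaker effect at the one concentration tested), compound 1 gives -16.8%, and compound 2 gives 3.99%. The change between them, (methyl in place of hydrogen on an oxygen on an aromatic ring), brought a rise of a number 20.8 percentage points higher from compound 1 to compound 2 (beyond the scatter). In this assay compound 3 gives 24.5%, the highest of the three numbers and beyond the scatter from both others. Compound 4 carries the same change relative to compound 3, (methyl in place of hydrogen on an oxygen on an aromatic ring), made at the same place; among the compounds shown this change occurs twice in all. Because the earlier step of a number 20.8 percentage points higher from compound 1 to compound 2 (beyond the scatter) was a modest rise, a step of similar size, a number 20.5 percentage points higher from compound 3 to compound 4 (beyond the scatter), is expected here, an expectation resting on one measured pair only. Compound 4 is accordingly expected to give about 45% in this assay, most likely between 22% and 68%.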

Compound 4, a percentage reported as activity, at one concentration (the size of the read-out at that concentration, not a potency): 67.3%
For compound 4 the middle estimate is 22.3 percentage points below the measured one; measured number inside the range.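

In this assay, hydroxy to methoxy on the 3-chloro-5-hydroxyphenyl group again weakened the effect, giving a number 42.8 percentage points higher from compound 3 to compound 4 (beyond the scatter), so the direction of the earlier step held on the second core. The size of the step did not carry over, however: the same change on two cores in this assay, a number 20.8 percentage points higher (beyond the scatter) from compound 1 to compound 2 and a number 42.8 percentage points higher (beyond the scatter) from compound 3 to compound 4, 22 percentage points apart, beyond the scatter of two such steps These two pairs show that the direction of this change repeated on the core of compound 1 and the core of compound 3, but they do not establish a rule for other cores, and they do not show which feature of the cores goes with the larger step.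

As far as these compounds go, whether a longer chain on the oxygen, such as ethyl, or an amine in place of the hydroxy would shift the read-out in the same direction and by a different amount on each core remains open. From the compounds shown here alone, how hydroxy to methoxy would behave on any third core also remains open.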